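The source may hold more compounds than are shown below. What is called first, only, known or untested is meant among the compounds shown, and "the series" means these compounds.

Working notes on the series. Going by the values given here, in a functional assay on SNB-75 cells (Homo sapiens) for inhibition, read by sulforhodamine B assay, with a stated time of 48 h (a lower number here means a stronger inhibitor of growth, a higher number a weaker inhibitor of growth), compound 1 (`Cc1ccc(C2=NN(c3ccc(S(C)(=O)=O)cc3)C(=O)CC2)cc1`) gives 540 nM, while compound 2 (`Cc1cc(O)ccc1C1=NN(c2ccc(S(C)(=O)=O)cc2)C(=O)CC1`) gives 5530 nM, the higher of the two numbers so far. Among the compounds with values here, the one measured step, a 10-fold higher number from compound 1 to compound 2 (1.01 log units; beyond the scatter), is large and beyond the scatter, and it replaces 4-methylphenyl with 4-hydroxy-2-methylphenyl. Compound 3 (`CCc1ccc(C2=NN(c3ccc(S(C)(=O)=O)cc3)C(=O)CC2)cc1`) follows with 4-ethylphenyl in place of 4-hydroxy-2-methylphenyl on a carbon with a double bond to nitrogen. Within the data shown here, the group that leaves is the one that entered in a 10-fold higher number from compound 1 to compound 2 (1.01 log units; beyond the scatter), and no measured compound yet carries 4-ethylphenyl, so the expectation rests on that single step. Expected in this assay is a 9.2-fold lower number from compound 2 to compound 3 (0.96 log units; beyond the scatter), a move to a lower number, close in size to the measured step but opposite in direction. Compound 3 is estimated at 600 nM, within a range of 200 nM to 1800 nM.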

Compound 3, concentration for 50% growth inhibition: 1320 nM
Compound 3: middle estimate off by 2.2-fold (0.34 log units), on the low side, and the stated range covers the measured number.
By their numbers in this assay, from the lowest: compound 1; then compound 3; then compound 2.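

On the carbon with a double bond to nitrogen, even one added methyl on the chain registers in this assay: 4-ethylphenyl in place of 4-methylphenyl gives a 2.4-fold higher number from compound 1 to compound 3 (0.39 log units; beyond the scatter) and so does not match the methyl compound, although both groups have no hydrogen-bond donor. The change from 4-hydroxy-2-methylphenyl to 4-ethylphenyl gives a 4.2-fold lower number from compound 2 to compound 3 (0.62 log units; beyond the scatter) and takes back only part of a 10-fold higher number from compound 1 to compound 2 (1.01 log units; beyond the scatter) at this position, leaving compound 3 between compound 1 and compound 2. Nothing at hand accounts for either new step.

Compound 2 carries the hydroxy group and the ring methyl together, so the compounds shown do not say which of the two goes with its higher number. Also open, going by these compounds, is how the number moves with a propyl chain or an amine on this phenyl ring.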